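The compounds below may be only part of what the source reports. "The series", "measured", "known", "first", "only" and "open" are said of these compounds alone.

Measured compounds in a physicochemical assay for solubility, read by HPLC, in phosphate buffer, measured as thermodynamic solubility, with a stated time of 24 h, at pH 6.8; a lower number here means a less soluble compound, a higher number a more soluble compound:
compound 1, `C=CC(=O)N1CC[C@H](N2C(=O)N(c3ccccc3)Cc3cnc(Nc4ccc(N5CCN(C)CC5)cc4)nc32)C1`, 976 ug/mL;
compound 2, `C=CC(=O)N1CC[C@H](N2C(=O)N(c3ccccc3)Cc3cnc(Nc4ccc(N5CCN(C)CC5)cc4OC)nc32)C1`, 1540 ug/mL.

Compound 1 stands at the lower of the two numbers, with compound 2 giving a 1.6-fold higher number from compound 1 to compound 2 (0.20 log units; within the scatter). Compound 3, `C=CC(=O)N1CC[C@H](N2C(=O)N(c3ccccc3)Cc3cnc(Nc4ccc(N5CCN(C)CC5)c(C(F)(F)F)c4)nc32)C1`, has not been measured. It differs from compound 1 by trifluoromethyl in place of hydrogen on an aromatic carbon. For the measured compounds named here, no measured step covers a trifluoromethyl; the only step at hand, the one from compound 1 to compound 2, stayed within the scatter, so it gives little guidance. A somewhat lower number is expected for compound 3, about a 2.0-fold lower number from compound 1 to compound 3 (0.29 log units; within the scatter). The solubility of compound 3 is thus estimated at 500 ug/mL, with a range from 150 ug/mL to 1500 ug/mL.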

Compound 3, solubility: 60.9 ug/mL
Estimate against measurement, compound 3: 8.2-fold (0.91 log units) above, outside the stated range (below it).
By their numbers in this assay, from the lowest: compound 3; then compounds 1 and 2 (each within the scatter of the next).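

In this assay, trifluoromethyl in place of hydrogen on this aromatic carbon, ortho to the 4-methylpiperazin-1-yl group, gives a 16-fold lower number from compound 1 to compound 3 (1.20 log units; beyond the scatter). It is the first step among these compounds that lies beyond the scatter, so a change at this carbon can move the read-out by a large margin. Nothing at hand bears on why the number fell. Going by these compounds, whether a fluorine, a methyl or an amine at this same carbon would give a step of similar size remains open.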